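Piperidin-4-yl to methyl: the next step in the series

A few compounds are considered here, and "the series" means these few. Any claim that something is new, unique, unknown or untested is made for them only; others in the source may bear on it.

Among the measured compounds shown here, in a functional assay on SK-BR-3 cells (Homo sapiens) for antiproliferative activity, read by MTT assay, with a stated time of 72 h (a higher number here means a weaker inhibitor, a lower number a stronger inhibitor), compound 2 (`CC(Oc1ncnc2ccc(-c3cnn(C4CCNCC4)c3)cc12)c1c(Cl)ccc(F)c1Cl`) gives 2500 nM, the lower of the two numbers so far, and compound 1 (`CC(Oc1nc(N)nc2ccc(-c3cnn(C4CCNCC4)c3)cc12)c1c(Cl)ccc(F)c1Cl`) gives 7120 nM. Compound 3 (`CC(Oc1ncnc2ccc(-c3cnn(C)c3)cc12)c1c(Cl)ccc(F)c1Cl`) carries methyl in place of piperidin-4-yl on an aromatic nitrogen. For the measured compounds named here, the only measured step, a 2.8-fold lower number from compound 1 to compound 2 (0.45 log units; beyond the scatter), is modest and lies at another place, so it is no direct guide here. Going by the values given here, no measured step covers this change, and the direction is tentative. A modest rise in this assay is expected, estimated as a 2.4-fold higher number from compound 2 to compound 3 (0.38 log units; beyond the scatter). For compound 3 the estimated value is 6000 nM, with an expected range of 1800 nM to 20000 nM.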

Compound 3, half-maximal inhibitory concentration: 27200 nM
The estimate for compound 3 lay 4.5-fold (0.66 log units) below the measured number; the whole stated range lies below it.
By their numbers in this assay, from the lowest: compound 2; then compound 1; then compound 3.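

In this assay, the group on an aromatic nitrogen of the five-membered aromatic ring strongly affects the number: methyl in place of piperidin-4-yl gives an 11-fold higher number from compound 2 to compound 3 (1.04 log units; beyond the scatter), a large step. It exceeds the modest 2.8-fold lower number from compound 1 to compound 2 (0.45 log units; beyond the scatter), which lies at another place, so this position counts for more in this series than the amino position of the core. No measurement shown explains the difference.

Still open, going by these compounds, is whether an open-chain amine or a carboxylic acid on that nitrogen would keep the number of compound 2. On these data alone, the effect of amino on the core with methyl on that nitrogen is also open.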